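The source may hold more compounds than are shown below. What is called first, only, known or untested is meant among the compounds shown, and "the series" means these compounds.

Series notes, metabolic stability read-out.

Compound 1 `Cc1cc(C(=O)O)ccc1OCCCCOc1ccc(C(=O)CC(C)C)c(O)c1C`: 41%
Compound 2 `Cc1c(OCCCCOCOc2ccc(C(=O)O)cc2)ccc(C(=O)CC2CCCC2)c1O`: 31%
Compound 3 `Cc1c(OCCCCOc2cccc(C(=O)O)c2)ccc(C(=O)CC(C)C)c1C`: 29%

In an ADME assay (liver) for metabolic stability, with Liver microsome (Rattus norvegicus) as the target, read by LC-MS, using microsomes and NADPH, with stated times of 5 min and 60 min, tested at 4 uM (on this read-out higher numbers stand for a more stable compound and lower numbers for a less stable compound), compound 2 stands second highest of the three numbers, yet neither gap is meaningful: compound 3 lies nearest and compound 1 furthest, both within the usual scatter. No pair of these compounds differs in only one place, so no single step is available from measured data.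

Compound 4 `Cc1cc(OCCCCOc2ccc(C(=O)CC3CCCC3)c(O)c2C)ccc1C(=O)O` is not yet measured. Relative to compound 2 the change is 4-carboxy-3-methylphenyl in place of (4-carboxyphenoxy)methyl on an oxygen on a saturated carbon. Compound 4 shares the 4-carboxy-3-methylphenyl arrangement with compound 1, which gives 41% in this assay, while keeping the ketone side of compound 2. Compound 4 is therefore expected to give about 38%, between 24% and 54%. The expected step of a number 7 percentage points higher from compound 2 to compound 4 (within the scatter) is small and may not rise beyond the scatter.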

Compound 4, percent of the compound remaining: 55%
Compound 4: middle estimate off by 17 percentage points, on the low side, and the stated range ends below it.
By their numbers in this assay, from the lowest: compounds 3, 2 and 1 (each within the scatter of the next, the first and the last beyond it); then compound 4.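

In this assay, among the compounds shown here, 4-carboxy-3-methylphenyl in place of (4-carboxyphenoxy)methyl on an oxygen on a saturated carbon gives a number 24 percentage points higher from compound 2 to compound 4 (beyond the scatter) as the only single-place comparison. For the compounds shown here, the group at this position therefore bears on the read-out, which the earlier compounds could not show. Nothing measured accounts for the step.

As far as these compounds go, the change alters several features at once, so the part of the step tied to the 3-methyl group stays open. Also open, from the compounds shown here alone, is how a primary amide in place of the carboxy group would read.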